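Swapping a Benzylsulfanyl Group for a Hydroxyethylamino Chain

A few compounds are considered here, and "the series" means these few. Any claim that something is new, unique, unknown or untested is made for them only; others in the source may bear on it.

Compound 1 `OC[C@H]1OC(n2cnc3c(SCc4ccccc4)nccc32)[C@H](O)[C@@H]1O` is a sugar-bearing molecule built on a fused two-ring core. In a functional assay on EL4 cells (Mus musculus) for inhibition, tested at 100 uM (a higher number here means more inhibition at the concentration tested (going by the name of the read-out), a lower number less inhibition), compound 1 gives 30%, the higher of the two numbers recorded. Compound 2 `[O-][n+]1ccc2[nH]cnc2c1`, a far smaller molecule, gives 5% in this assay, a gap beyond the scatter. Compound 3 `OCCNc1nccc2c1ncn2C1O[C@H](CO)[C@@H](O)[C@H]1O` differs from compound 1 in one place: (2-hydroxyethyl)amino in place of benzylsulfanyl on an aromatic carbon. Among the compounds with values here, no measured pair shows the effect of this change, so the expectation is tentative. A drop of the size a number 15 percentage points lower from compound 1 to compound 3 (beyond the scatter) is expected, partly because compound 2 gives only 5%. Compound 3 is expected to give 15%, within 0% to 35%.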

Compound 3, a percentage reported as inhibition, at one concentration (the size of the read-out at that concentration, not a potency): 6%
Compound 3: middle estimate off by 9 percentage points, on the high side; low and high end bracket the measured number.
By their numbers in this assay, from the lowest: compounds 2 and 3 (each within the scatter of the next); then compound 1.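

In this assay the swap of benzylsulfanyl for (2-hydroxyethyl)amino on this aromatic carbon, next to the ring nitrogen, gives a number 24 percentage points lower from compound 1 to compound 3 (beyond the scatter) and so costs inhibition. Within the data shown here, this is the first direct reading of this position: with the sugar and the shared core unchanged, the group held here clearly affects the result. Nothing measured here explains the step.

The swap changes the whole group at once, so the sulfur, the aromatic ring and the hydroxyethyl chain cannot be told apart. A benzylamino group on this carbon would help to separate them.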